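The source may hold more compounds than are shown below. What is called first, only, known or untested is meant among the compounds shown, and "the series" means these compounds.

Within the data shown here, in an assay on cells for activation of probable G-protein coupled receptor 34 (Mus musculus), with a stated time of 1 h (a lower number here means a smaller maximal response, a higher number a larger maximal response), compound 1 `CCCCCCCCCCCOc1ccccc1CCC(=O)OCCCOP(=O)(O)OC[C@H](N)C(=O)O` gives 0.04, and compound 2 `N[C@@H](COP(=O)(O)OCCCOC(=O)CCc1ccccc1OCCCCOc1ccccc1)C(=O)O` gives 0.033; the two numbers sit within the scatter of each other, so compound 2 stands level with compound 1, and the only measured step is a number 0.0070 lower from compound 1 to compound 2 (within the scatter). Compound 3 `N[C@@H](COP(=O)(O)OCCCOC(=O)CCc1ccccc1OCCCCCCOc1ccccc1)C(=O)O` differs from compound 2 by 2-phenoxyethyl in place of phenoxy on a saturated chain carbon, four bonds along the chain from an oxygen on an aromatic ring. Among the measured compounds shown here, that single step, which bears on this change, moved nothing beyond the scatter, and no measured pair tests a longer chain at this place. Compound 3 is therefore expected to show only a number 0.0070 higher from compound 2 to compound 3 (within the scatter). The estimate for compound 3 is 0.04, ranging from 0 to 0.15.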

Compound 3, intrinsic activity: the largest response reached, as a fraction of the reference agonist's: 0.071
Beside the measured number, compound 3's estimate is 0.031 below it, and the stated range covers the measured number.
By their numbers in this assay, from the lowest: compounds 2, 1 and 3 (each within the scatter of the next).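

In this assay, 2-phenoxyethyl in place of phenoxy gives a number 0.038 higher from compound 2 to compound 3 (within the scatter), so this longer chain, on a saturated chain carbon four bonds along the chain from an oxygen on an aromatic ring, leaves the maximal response level. Phenoxy in place of pentyl, six bonds along the chain from that oxygen, gives a number 0.031 higher from compound 1 to compound 3 (within the scatter), so this change also leaves the response level. Nothing available here explains these numbers. From the compounds shown here alone, whether a longer chain such as 4-phenoxybutyl, or an amine in place of phenoxy, would move the response beyond the scatter stays open.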